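The compounds below may be only part of what the source reports. "The series", "measured", "known", "first", "only" and "open" are said of these compounds alone.

Of the compounds shown here, three built on one shared core have been tested in an ADME assay on L929 cells (Mus musculus) for cytotoxicity, read by resazurin assay, with a stated time of 72 h; a lower number here means a stronger inhibitor, a higher number a weaker inhibitor. Compound 1 `O=C(O)c1ccc(C(=O)/C=C/c2ccc3c(c2)B(O)OC3)cc1` carries a carboxy group; in this assay compound 1 gives > 10 ug/mL, which is a limit of the assay rather than a number, so compound 1 stands at the limit of > 10 ug/mL in this assay, at which 2 of the 3 values shown sit. Compound 2 `Cc1cccc(C(=O)/C=C/c2ccc3c(c2)B(O)OC3)c1` gives 8.56 ug/mL in this assay. Compound 3 `O=C(/C=C/c1ccc2c(c1)B(O)OC2)c1ccc(O)c(O)c1` also gives only a limit in this assay, > 10 ug/mL. Compound 4 `CSc1ccc(C(=O)/C=C/c2ccc3c(c2)B(O)OC3)cc1` differs from compound 1 by methylsulfanyl in place of carboxy on an aromatic carbon. Among the compounds with values here, no step between measured compounds is available to gauge this change, so compound 4 is expected to remain near the limit, with an expected step of an at least 1.1-fold lower number from compound 1 to compound 4 (0.04 log units; that floor lies within the scatter) that lies within the scatter. The estimate for compound 4 in this assay is 9 ug/mL, between 5 ug/mL and 15 ug/mL.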

Compound 4, half-maximal inhibitory concentration: > 10 ug/mL
Compound 4: no number, only a limit; the forecaster's own chance of this, stated with the estimate: 45%; middle value at least 1.1-fold (0.04 log units) from the limit.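

Compound 1 and compound 4 each give only a limit in this assay, so the step between them cannot be read: the limit of > 10 ug/mL in this assay, at which 3 of the 4 values shown sit. On these data alone, how methylsulfanyl truly compares with carboxy on the shared core stays open.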